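Methyl in Place of a Phenolic Hydrogen: Cytotoxicity Readings

A few compounds are considered here, and "the series" means these few. Any claim that something is new, unique, unknown or untested is made for them only; others in the source may bear on it.

Three compounds were measured in a functional assay on A549 cells (Homo sapiens) for cytotoxicity, read by XTT assay, with a stated time of 24 h; on this read-out higher numbers stand for weaker inhibition and lower numbers for stronger inhibition.
Compound 1, `Cn1nnnc1SCC(=O)N/N=C/c1ccccc1O`, gives > 10000000 nM, which is a limit of the assay.
Compound 2, `Cn1nnnc1SCC(=O)N/N=C/c1cccc(O)c1`, gives 4500000 nM.
Compound 3, `COc1ccccc1/C=N/NC(=O)CSc1nnnn1C`, gives 7000000 nM.

Compound 3 differs from compound 1 by methyl in place of hydrogen on an oxygen on an aromatic ring. This change gave an at least 1.4-fold lower number from compound 1 to compound 3 (0.15 log units; that floor lies within the scatter). Compound 1 sits at the limit of > 10000000 nM in this assay, at which 1 of the 3 values shown sits, so that step is only a floor. Compound 2 and compound 3 lie within the scatter of each other in this assay. How the core of compound 2 differs from the core of compound 1 is not broken down here.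

Compound 4, `COc1cccc(/C=N/NC(=O)CSc2nnnn2C)c1`, is not yet measured; it differs from compound 2 by methyl in place of hydrogen on an oxygen on an aromatic ring, the same change as before. Compound 4 is expected to show a 1.1-fold higher number from compound 2 to compound 4 (0.05 log units; within the scatter), which rests on the step of an at least 1.4-fold lower number from compound 1 to compound 3 (0.15 log units; that floor lies within the scatter) lying within the scatter. Compound 4 is estimated at 5000000 nM, with a range from 2000000 nM to 12000000 nM.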

Compound 4, half-maximal inhibitory concentration: > 10000000 nM
Compound 4: a limit, no number; the forecaster's own chance of this, stated with the estimate: 20%; middle value at least 2.0-fold (0.30 log units) from the limit.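

In this assay the change gave an at least 2.2-fold higher number from compound 2 to compound 4 (0.34 log units; beyond the scatter), so it did not carry over unchanged from one core to the other: the same change on two cores in this assay, an at least 1.4-fold lower number (0.15 log units; that floor lies within the scatter) from compound 1 to compound 3 and an at least 2.2-fold higher number (0.34 log units; beyond the scatter) from compound 2 to compound 4, at least 3.1-fold (0.50 log units) apart, beyond the scatter of two such steps

Both steps are only floors, since one compound in each pair sits at a limit of the assay: the limit of > 10000000 nM in this assay, at which 2 of the 4 values shown sit.

From the compounds shown here alone, the two cores therefore differ in how they take this change, but the true size of either step stays unknown, and the data do not show why the cores differ or how any further core would behave.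

The compounds shown leave open how an ethoxy group, with a longer chain on the same oxygen, would read on either core. They also leave open how an amine in place of the hydroxy would read.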